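Ethoxy Analogue in the Maximal Electroshock Model

A few compounds are considered here, and "the series" means these few. Any claim that something is new, unique, unknown or untested is made for them only; others in the source may bear on it.

Measured compounds:
Compound 1 `c1cc(OC2CCCCC2)nc(N2CCNCC2)c1`: 30 mg/kg
Compound 2 `COc1cccc(N2CCNCC2)n1`: 30 mg/kg

In a functional assay on the whole organism with Mus musculus as the target, in the maximal electroshock model, with a stated time of 30 min (a lower number here means that less compound is needed, a higher number that more compound is needed for the effect), compound 1 gives 30 mg/kg and compound 2 gives 30 mg/kg. For the measured compounds named here, the one recorded step, no change at the digits printed from compound 1 to compound 2 (within the scatter), shows that replacing cyclohexyl with methyl on the oxygen on the aromatic ring left the minimum effective dose where it was. Compound 2 therefore stands level with compound 1 at the digits shown, and its nearest neighbour among the measured compounds is compound 1.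

Compound 3 `CCOc1cccc(N2CCNCC2)n1` is yet to be measured. It differs from compound 2 by methyl in place of hydrogen on a saturated chain carbon bound to an oxygen on an aromatic ring. The step from compound 1 to compound 2 is the only one that bears on this change, since it also alters the group on the oxygen on the aromatic ring, and it produced no change beyond the scatter. The expectation for compound 3 is accordingly a step of no change at the digits printed from compound 2 to compound 3 (within the scatter), that is, none beyond the scatter. Compound 3 is estimated to give 30 mg/kg, within a range of 15 mg/kg to 60 mg/kg.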

Compound 3, minimum effective dose: 30 mg/kg
Compound 3: the middle estimate sits on the measured number at the digits printed; the measured number falls inside the stated range.
By their numbers in this assay, from the lowest: compounds 1, 2 and 3 (each within the scatter of the next).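

Methyl in place of hydrogen on a saturated chain carbon bound to an oxygen on an aromatic ring, the change of methoxy to ethoxy, is a step of no change at the digits printed from compound 2 to compound 3 (within the scatter) and gives the first reading of this change on its own. Ethyl in place of cyclohexyl on the same oxygen is a step of no change at the digits printed from compound 1 to compound 3 (within the scatter), so this assay does not tell methyl, ethyl and cyclohexyl apart on that oxygen. Nothing available accounts for this lack of separation.

The compounds shown leave open whether a different group on the oxygen, such as a chain bearing an amine or a carboxylic acid, would shift the minimum effective dose. As far as these compounds go, with one read-out for each compound, it also remains open whether compound 1, compound 2 and compound 3 would separate in any other measure.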